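Removing the nitro group from compound 3

A few compounds are considered here, and "the series" means these few. Any claim that something is new, unique, unknown or untested is made for them only; others in the source may bear on it.

Measured compounds, in a functional assay on DU-145 cells (Homo sapiens) for antiproliferative activity, read by MTT assay, with a stated time of 72 h; a lower number here means a stronger inhibitor, a higher number a weaker inhibitor:
- Compound 1 `c1ccc(COc2ccc(Nc3ncnc4cc5c(cc34)OCCOCCOCCO5)cc2)cc1` gives > 100000 nM as a limit
- Compound 2 `FC(F)(F)c1ccc(COc2cccc(Nc3ncnc4cc5c(cc34)OCCOCCO5)c2)cc1` gives > 100000 nM as a limit
- Compound 3 `O=[N+]([O-])c1ccc(COc2cccc(Nc3ncnc4cc5c(cc34)OCCOCCO5)c2)cc1` gives > 100000 nM as a limit

Compound 3 has no numerical value in this assay, only the limit > 100000 nM and nothing more. The other two results are also limits, so all three sit together (the limit of > 100000 nM in this assay, at which 3 of the 3 values shown sit).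

Compound 4 `c1ccc(COc2cccc(Nc3ncnc4cc5c(cc34)OCCOCCO5)c2)cc1` has hydrogen in place of nitro on an aromatic carbon, para to a large group (hydrogen in place of nitro on an aromatic carbon), which turns 4-nitrobenzyl into benzyl. Within the data shown here, the one measured step at this group is a step that the two limits leave unreadable from compound 2 to compound 3 with nitro in place of trifluoromethyl, and it offers no size to carry over. No direction can be drawn from it either, so no step beyond the scatter is expected in this assay here.

The expected outcome is a number no higher from compound 3 to compound 4 (the limit leaves the size open) and is most likely another limit. For compound 4 the estimated value is 100000 nM with an expected range of 30000 nM to 200000 nM in this series.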

Compound 4, half-maximal inhibitory concentration: > 100000 nM
Compound 4: no number, only a limit; the forecaster's own chance of this, stated with the estimate: 70%; the middle value sits exactly at the limit.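

In this assay compound 4 gives > 100000 nM, a limit and not a number. The steps from compound 2 and compound 3 to compound 4 cannot be read, and all four compounds sit together: the limit of > 100000 nM in this assay, at which 4 of the 4 values shown sit.

The compounds shown leave open the size and direction of any change at this group in this assay.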